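The source may hold more compounds than are shown below. What is called first, only, known or untested is meant among the compounds shown, and "the series" means these compounds.

Measured compounds in this series:

Compound 1 `N[C@]1(C(=O)O)[C@H]2[C@@H](C[C@H]1OCCCc1ccccc1)[C@]2(F)C(=O)O`: 9.83 nM
Compound 2 `N[C@]1(C(=O)O)[C@H]2[C@@H](C[C@H]1OCc1cccc(Oc3ccccc3)c1)[C@]2(F)C(=O)O`: 7.15 nM
Compound 3 `N[C@]1(C(=O)O)[C@H]2[C@@H](C[C@H]1OCc1cccc([N+](=O)[O-])c1)[C@]2(F)C(=O)O`: 7.87 nM

In an assay on CHO cells for binding affinity to metabotropic glutamate receptor 2 (Rattus norvegicus) (a lower number here means a stronger inhibitor, a higher number a weaker inhibitor), compound 1 gives 9.83 nM, the highest of the three numbers; its gap to compound 3 and its gap to compound 2 are both within the scatter, so the three measured compounds are indistinguishable on this read-out.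

Compound 4 `N[C@]1(C(=O)O)[C@H]2[C@@H](C[C@H]1OCc1cc(F)cc(F)c1)[C@]2(F)C(=O)O` is not yet measured. It differs from compound 1 by 3,5-difluorophenyl in place of phenethyl on a saturated chain carbon bound to an oxygen on a saturated carbon.

For the measured compounds named here, only one measured step concerns a change on the aromatic ring of this side chain: a 1.1-fold higher number from compound 2 to compound 3 (0.04 log units; within the scatter). Going by the values given here, no measured step covers the shortening of the chain from compound 1 to a benzyl-type ether, but the values of compound 2 and compound 3, which carry such an ether, sit within the scatter of compound 1. Together these give no ground for a step beyond the scatter in this assay in either direction.

Compound 4 is therefore expected to give about 8 nM, with a range of 4 nM to 16 nM, an estimated step of a 1.2-fold lower number from compound 1 to compound 4 (0.09 log units; within the scatter).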

Compound 4, inhibition constant: 12.4 nM
Beside the measured number, compound 4's estimate is 1.6-fold (0.19 log units) below it; the range from low to high includes it.
By their numbers in this assay, from the lowest: compounds 2, 3, 1 and 4 (each within the scatter of the next).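

In this assay, 3,5-difluorophenyl in place of phenethyl on a saturated chain carbon bound to an oxygen on a saturated carbon gives a 1.3-fold higher number from compound 1 to compound 4 (0.10 log units; within the scatter) and so stays within the scatter. Unlike the step between compound 2 and compound 3, which concerns only a substituent on the aromatic ring, this step changes the whole group at this position, and the number still does not leave the scatter. For the compounds shown here, the two groups have the same heavy-atom count and the same aromatic ring type, and neither carries a hydrogen-bond donor or acceptor, so this step shows only that this particular exchange leaves the binding number within the scatter, and nothing measured here bears on why.

All the side chains shown so far give numbers within the scatter of their neighbours in the series, so it remains open which part of the side chain, if any, can move this number beyond the scatter. A carboxylic acid or an amine on the aromatic ring, or a longer chain between the ether oxygen and the ring, would test whether this position tolerates such groups as well.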